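A few compounds are considered here, and "the series" means these few. Any claim that something is new, unique, unknown or untested is made for them only; others in the source may bear on it.

In a functional assay on BaF3 cells (Mus musculus) for inhibition, read by CCK-8 assay, with a stated time of 72 h (on this read-out lower numbers stand for stronger inhibition of growth and higher numbers for weaker inhibition of growth), compound 1 `CNc1cc(Oc2ccc(NC(=O)Nc3ccc(C)c(C(F)(F)F)c3)cc2)ncn1` gives only a limit, > 10000 nM. Compound 2 `Cc1ccc(NC(=O)Nc2ccc(Oc3cc(NCc4ccccc4)ncn3)cc2)cc1C(F)(F)F` reads 3010 nM, and compound 3 `Cc1ccc(NC(=O)Nc2ccc(Oc3cc(/N=C/N(C)C)ncn3)cc2)cc1C(F)(F)F` reads 6610 nM, the higher of the two actual numbers. Compound 4 `CNCCN(C)c1cc(Oc2ccc(NC(=O)Nc3ccc(C)c(C(F)(F)F)c3)cc2)ncn1` carries methyl(2-(methylamino)ethyl)amino on the aromatic carbon that holds the changing group in compound 3: a group of 6 heavy atoms (4 carbon, 2 nitrogen; no ring) in place of a group of 5 heavy atoms (3 carbon, 2 nitrogen; no ring), on an aromatic carbon. Three measured changes at this carbon bear on it: an at least 3.3-fold lower number from compound 1 to compound 2 (0.52 log units; beyond the scatter), a 2.2-fold higher number from compound 2 to compound 3 (0.34 log units; beyond the scatter) and an at least 1.5-fold lower number from compound 1 to compound 3 (0.17 log units; that floor lies within the scatter), the last with its floor within the scatter. All are small, so only a modest shift towards a lower number is expected in this assay. The expected step is a 2.2-fold lower number from compound 3 to compound 4 (0.34 log units; beyond the scatter). For compound 4 the estimate is 3000 nM, with an expected range of 800 nM to 9000 nM.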

Compound 4, concentration for 50% growth inhibition: > 10000 nM
Compound 4: no number, only a limit; the forecaster's own chance of this, stated with the estimate: 15%; at least 3.3-fold (0.52 log units) between middle value and limit.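

In this assay, methyl(2-(methylamino)ethyl)amino on this aromatic carbon does not hold the level of benzylamino, with an at least 3.3-fold higher number from compound 2 to compound 4 (0.52 log units; beyond the scatter). Against the group it replaces, the reading is only an at least 1.5-fold higher number from compound 3 to compound 4 (0.17 log units; that floor lies within the scatter), which leaves that pair unordered. Compound 4 gives only a limit, so this flexible-chain change brings the series back to the ceiling of the read-out: the limit of > 10000 nM in this assay, at which 2 of the 4 values shown sit.

The step between the two compounds at the limit cannot be read. From the compounds shown here alone, whether a morpholine, a piperazine or a substituted benzylamino on this carbon would give a lower number stays open.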